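Swapping the heteroaryl arm on a diphenylmethyl sulfoxide

This account rests on a few compounds, and the source may have more. Where it says the series, first, only, none or still open, it means among the compounds named here.

Measured compounds:
compound 1 `[O-][S+](Cc1ccc(Cl)s1)C(c1ccccc1)c1ccccc1` with 12800 nM
compound 2 `Cc1noc(C[S+]([O-])C(c2ccccc2)c2ccccc2)n1` with 56700 nM

Among the compounds with values here, only two compounds have been tested in an assay on HEK293 cells for inhibition of sodium-dependent dopamine transporter (Homo sapiens), read by scintillation counting, with stated times of 5 min and 1 min (on this read-out lower numbers stand for stronger inhibition and higher numbers for weaker inhibition), and compound 2 gives the highest number of the two; its nearest neighbour is compound 1, and the step of a 4.4-fold higher number from compound 1 to compound 2 (0.65 log units; beyond the scatter) lies beyond the scatter. Compound 3 `Cc1cnc(C[S+]([O-])C(c2ccccc2)c2ccccc2)nc1` has not yet been measured. It differs from compound 2 in one place: 5-methylpyrimidin-2-yl in place of 3-methyl-1,2,4-oxadiazol-5-yl on a saturated chain carbon bound to a sulfur. Within the data shown here, the only measured step that bears on this position is the one from compound 1 to compound 2, where exchanging one aromatic arm for another moved the number by a 4.4-fold higher number from compound 1 to compound 2 (0.65 log units; beyond the scatter). That step shows this arm matters, but it does not tell how a six-membered ring with two nitrogens will compare with the five-membered ring of compound 2. With so little to go on, compound 3 is expected to give a number near that of compound 2, perhaps somewhat lower, a step estimated as a 1.9-fold lower number from compound 2 to compound 3 (0.28 log units; within the scatter). Compound 3 is therefore estimated at 30000 nM, within a range from 9000 nM to 100000 nM.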

Compound 3, half-maximal inhibitory concentration: 156000 nM
Beside the measured number, compound 3's estimate is 5.2-fold (0.72 log units) below it; the measured number lies above the stated range.
By their numbers in this assay, from the lowest: compound 1; then compound 2; then compound 3.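

In this assay, the arm on a saturated chain carbon bound to a sulfur now has three measured forms, and replacing 3-methyl-1,2,4-oxadiazol-5-yl with 5-methylpyrimidin-2-yl gives a 2.8-fold higher number from compound 2 to compound 3 (0.44 log units; beyond the scatter). The larger arm, with its six-membered aromatic ring, therefore brings no gain here, and the full effect of the arm is clearer in the change from 5-chlorothiophen-2-yl to 5-methylpyrimidin-2-yl, which gives a 12-fold higher number from compound 1 to compound 3 (1.09 log units; beyond the scatter), a large step compared with the modest ones before it. All three compounds are still weak by these numbers, with the 5-chlorothiophen-2-yl arm of compound 1 giving the lowest value, and nothing available here explains why the numbers fall in this order.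

The compounds shown leave open whether the advantage of compound 1 rests on its chlorine or on its thiophene ring, which a thiophene without the chlorine, or a plain phenyl ring, would help to separate. They also leave open how an arm of a different kind, such as one carrying an amine or a carboxylic acid, would compare with these three.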